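Expected Cytotoxicity of Compound 4 from Three Measured Analogues

This account rests on a few compounds, and the source may have more. Where it says the series, first, only, none or still open, it means among the compounds named here.

In a functional assay on C8166 cells (Homo sapiens) for cytotoxicity, read by MTT assay (on this read-out lower numbers stand for higher toxicity in this test and higher numbers for lower toxicity in this test), the three measured compounds stand as follows:
Compound 1 `Cc1cc(S(N)(=O)=O)ccc1NC(=O)COc1ccc(Cl)cc1NC(=O)c1ccccc1` gives 207000 nM.
Compound 2 `Cc1cc(S(N)(=O)=O)ccc1NC(=O)COc1ccc(Cl)cc1NC(=O)c1cccc(F)c1` gives 243000 nM.
Compound 3 `Cc1ccc(C(=O)Nc2cc(Cl)ccc2OCC(=O)Nc2ccc(S(N)(=O)=O)cc2C)cc1C` gives 84100 nM.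

Compound 2 has the highest number of the three; its gap to compound 1 is within the scatter, while its gap to compound 3 is beyond it, as a 2.9-fold lower number from compound 2 to compound 3 (0.46 log units; beyond the scatter) shows. Compound 4 `Cc1cc(S(N)(=O)=O)ccc1NC(=O)COc1ccc(Cl)cc1NC(=O)c1ccc(Cl)cc1Cl` differs from compound 2 in one place: 2,4-dichlorophenyl in place of 3-fluorophenyl on a carbonyl carbon. The measured steps that bear on this both change the ring on that carbonyl carbon: a 2.5-fold lower number from compound 1 to compound 3 (0.39 log units; beyond the scatter) and a 2.9-fold lower number from compound 2 to compound 3 (0.46 log units; beyond the scatter), each a modest lowering. A modest lowering is therefore expected in this assay as well. The estimated step is a 2.0-fold lower number from compound 2 to compound 4 (0.31 log units; beyond the scatter). Compound 4 is expected to give about 120000 nM, with a likely range from 50000 nM to 300000 nM.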

Compound 4, half-maximal cytotoxic concentration: 61100 nM
Compound 4: the middle estimate sits 2.0-fold (0.29 log units) above what was measured, and the stated range covers the measured number.
By their numbers in this assay, from the lowest: compounds 4 and 3 (each within the scatter of the next); then compounds 1 and 2 (each within the scatter of the next).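

In this assay, a ring with two chlorines on this carbonyl carbon also goes with lower numbers, as shown by a 4.0-fold lower number from compound 2 to compound 4 (0.60 log units; beyond the scatter) and by a 3.4-fold lower number from compound 1 to compound 4 (0.53 log units; beyond the scatter). Swapping 3,4-dimethylphenyl for 2,4-dichlorophenyl gives a 1.4-fold lower number from compound 3 to compound 4 (0.14 log units; within the scatter), so these two differently substituted rings read alike, while the single fluoro of compound 2 goes against any rule that every added group lowers the number. Nothing measured here explains these steps. The compounds shown leave open whether one chlorine alone would give the same step, and how a ring bearing an amine or a carboxylic acid would read.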